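A few compounds are considered here, and "the series" means these few. Any claim that something is new, unique, unknown or untested is made for them only; others in the source may bear on it.

Measured in an ADME assay on microsomes from liver (Mus musculus) for metabolic stability, with a stated time of 10 min; a higher number here means that more of the compound is left, a lower number that less of the compound is left:
- compound 1 `CC(=O)N1CC[C@H](C(=O)N2CC[C@](c3ccc(C(OCc4c(F)cccc4F)(C(F)(F)F)C(F)(F)F)cc3)(S(=O)(=O)c3ccc(F)cc3)C2)C1`: 57%
- compound 2 `CC(=O)N1CC[C@@H](C(=O)N2CC[C@](c3ccc(C(OCc4c(F)cccc4F)(C(F)(F)F)C(F)(F)F)cc3)(S(=O)(=O)c3ccc(F)cc3)C2)C1`: 55%

Compound 2 gives 55%, within the scatter of compound 1. Compound 3 `CC(=O)N1CCC(C)(C(=O)N2CC[C@](c3ccc(C(OCc4c(F)cccc4F)(C(F)(F)F)C(F)(F)F)cc3)(S(=O)(=O)c3ccc(F)cc3)C2)CC1` carries 1-acetyl-4-methylpiperidin-4-yl in place of 1-acetylpyrrolidin-3-yl on a carbonyl carbon. For the measured compounds named here, the one measured step, a number 2 percentage points lower from compound 1 to compound 2 (within the scatter), reflects the fact that compounds 1 and 2 differ only in the configuration as drawn and is small, but it does not cover an exchange of this kind. With no measured guide to direction, no shift beyond the scatter is expected, and the range is kept wide. The expected step is a number 2 percentage points lower from compound 2 to compound 3 (within the scatter). For compound 3 the estimate is 53%, with an expected range from 30% to 75%.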

Compound 3, percent of the compound remaining: 4%
Compound 3: the middle estimate sits 49 percentage points above what was measured, outside the stated range (below it).
By their numbers in this assay, from the lowest: compound 3; then compounds 2 and 1 (each within the scatter of the next).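

In this assay, 1-acetyl-4-methylpiperidin-4-yl in place of 1-acetylpyrrolidin-3-yl on a carbonyl carbon gives a number 51 percentage points lower from compound 2 to compound 3 (beyond the scatter), and likewise a number 53 percentage points lower from compound 1 to compound 3 (beyond the scatter). The group on this carbonyl carbon therefore strongly affects the percent remaining, which the earlier pair could not reveal, its small step going with a single fact: the fact that compounds 1 and 2 differ only in the configuration as drawn

The exchange couples a five-membered to six-membered ring change with the added methyl, and the compounds shown do not separate these two differences. The unmethylated 1-acetylpiperidin-4-yl group would be needed to separate them.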